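The source may report more compounds than this note shows. Statements on the series, on what has been measured and on what is new or still open speak of the compounds shown alone.

In a functional assay on A549 cells (Homo sapiens) for inhibition, read by MTT assay (a lower number here means a stronger inhibitor, a higher number a weaker inhibitor), compound 1 `O=C(CN1CCC(Cc2ccccc2)CC1)Nc1ccc(C(=O)/C=C/c2cn(Cc3ccc(Br)cc3)nn2)cc1` gives 40000 nM. Among the three numbers measured so far this is the second highest, though all three stand within the usual scatter of one another. Compound 2 `CCCCCCCCCCn1cc(/C=C/C(=O)c2ccc(NC(=O)CN3CCN(C(=O)OC(C)(C)C)CC3)cc2)nn1` gives 45400 nM in this assay, and compound 3 `CCCCCCCCn1cc(/C=C/C(=O)c2ccc(NC(=O)CN3CCN(c4ccccc4OC)CC3)cc2)nn1` gives 34000 nM in this assay. The unmeasured compound 4 `CCCCCCCCn1cc(/C=C/C(=O)c2ccc(NC(=O)CN3CCC(Cc4ccccc4)CC3)cc2)nn1` keeps the amide side of compound 1 and differs only at the aromatic nitrogen: heptyl in place of 4-bromophenyl on a saturated chain carbon bound to an aromatic nitrogen. Going by the values given here, no measured pair differs by exactly this change, so its effect is not known from the data. What the data do show is that compound 3, which also carries an octyl group on its aromatic nitrogen, gives 34000 nM, a number close to that of compound 1, and that the three measured values lie close together. On this basis the step is expected to be small, a 1.1-fold lower number from compound 1 to compound 4 (0.02 log units; within the scatter), with no direction beyond the scatter. Compound 4 is estimated at 38000 nM, within the range 20000 nM to 75000 nM.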

Compound 4, half-maximal inhibitory concentration: 43800 nM
Compound 4: the middle estimate sits 1.2-fold (0.06 log units) below what was measured; the measured number falls inside the stated range.
By their numbers in this assay, from the lowest: compounds 3, 1, 4 and 2 (each within the scatter of the next).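

Going by these compounds alone, the pair gives the first direct reading at this position: in this assay there is a 1.1-fold higher number from compound 1 to compound 4 (0.04 log units; within the scatter), with the same amide side on both compounds. Replacing the 4-bromobenzyl group with octyl therefore exchanges an aromatic ring and its bromine for an open carbon chain, and this exchange produces no difference that can be read beyond the scatter. No available evidence bears on this result.

As far as these compounds go, it remains open whether a group of another kind on this saturated chain carbon, such as a chain ending in an amine or a carboxylic acid, would move the number beyond the scatter. A much shorter group, such as methyl, leaves the same question open.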